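This account rests on a few compounds, and the source may have more. Where it says the series, first, only, none or still open, it means among the compounds named here.

Compound 2 `Nc1ncnc2c1c(-c1cnc3[nH]ccc3c1)nn2CCCC(=O)NO` is one of three measured analogues sharing a common core. In a functional assay on A549 cells (Homo sapiens) for inhibition, read by MTT assay, with a stated time of 72 h (a lower number here means a stronger inhibitor, a higher number a weaker inhibitor), compound 2 gives only a limit of the assay, > 150000 nM, which is the limit of > 150000 nM in this assay, at which 1 of the 3 values shown sits. Compound 1 `CNC(=O)CCCCCCCn1nc(-c2ccc3oc(N)nc3c2)c2c(N)ncnc21` gives 8360 nM in this assay. Compound 3 `Nc1nc2cc(-c3nn(CCCCCCCCCC(=O)NO)c4ncnc(N)c34)ccc2o1` also returns only a limit of the assay, > 50000 nM. The change from compound 2 to compound 4 `Nc1ncnc2c1c(-c1cnc3[nH]ccc3c1)nn2CCCCCCC(=O)NO` is 3-(hydroxycarbamoyl)propyl in place of hydroxycarbamoyl on a saturated chain carbon, three bonds along the chain from an aromatic nitrogen. Within the data shown here, the one measured step that touches a longer hydroxycarbamoyl chain is an at least 5.9-fold higher number from compound 1 to compound 3 (0.77 log units; beyond the scatter), which went toward weaker inhibition. Among the measured compounds shown here, both hydroxycarbamoyl compounds measured so far sit at limits, so compound 4 is expected to stay weak, with an uncertain step of an at least 2.5-fold lower number from compound 2 to compound 4 (0.39 log units; beyond the scatter). Compound 4 is estimated at about 60000 nM, between 15000 nM and 300000 nM, possibly again only a limit.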

Compound 4, half-maximal inhibitory concentration: 50000 nM
Beside the measured number, compound 4's estimate is 1.2-fold (0.08 log units) above it; the range from low to high includes it.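

In this assay, 3-(hydroxycarbamoyl)propyl in place of hydroxycarbamoyl gives an at least 3.0-fold lower number from compound 2 to compound 4 (0.47 log units; beyond the scatter), so at this position a chain lengthened while keeping its hydroxycarbamoyl end can lower the number, and this is the first such gain shown. From the compounds shown here alone, the true size of the step stays unknown, as the value for compound 2 is a limit and not a number: the limit of > 150000 nM in this assay, at which 1 of the 4 values shown sits. Still, compound 4 remains a weak inhibitor in absolute terms. Open, going by these compounds, is whether a longer chain lowers the number further, and whether a carboxylic acid at the chain end would do the same as hydroxycarbamoyl.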